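The compounds below may be only part of what the source reports. "The series", "measured", "known", "first", "only" and "open" are said of these compounds alone.

In a functional assay on A549 cells (Homo sapiens) for cytotoxicity, read by MTT assay, with a stated time of 48 h (a lower number here means a stronger inhibitor, a higher number a weaker inhibitor), compound 3, `Cc1ccc(Cn2cc(COc3ccc4c(=O)ccoc4c3)nn2)cc1`, gives 50700 nM, the higher of the two numbers shown. Its nearest neighbour is compound 2, `Cc1cccc(Cn2cc(COc3ccc4c(=O)ccoc4c3)nn2)c1`, which in this assay gives 20300 nM; the step of a 2.5-fold higher number from compound 2 to compound 3 (0.40 log units; beyond the scatter) separates the two. Compound 1, `O=c1ccoc2cc(OCc3cn(Cc4ccccc4)nn3)ccc12`, is recorded only as a limit of this assay, > 100000 nM. From that limit the steps of an at least 4.9-fold lower number from compound 1 to compound 2 (0.69 log units; beyond the scatter) and an at least 1.9-fold lower number from compound 1 to compound 3 (0.29 log units; that floor lies within the scatter) run toward the two methyl-bearing analogues, the first beyond the scatter and the second not.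

Compound 4, `O=c1ccoc2cc(OCc3cn(Cc4ccc(Cl)cc4)nn3)ccc12`, follows from compound 3 by a single exchange: chloro in place of methyl on an aromatic carbon. None of the measured steps swaps chloro for methyl; the three steps shown concern only the presence and placement of a methyl group, and the one step at the same position, a 2.5-fold higher number from compound 2 to compound 3 (0.40 log units; beyond the scatter), compares two methyl placements rather than two groups. The evidence therefore gives no direction for the exchange. The expected step from compound 3 to compound 4 in this assay is a 1.3-fold lower number from compound 3 to compound 4 (0.10 log units; within the scatter), within the scatter. For compound 4 in this assay the estimate is 40000 nM, with a range from 12000 nM to 100000 nM.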

Compound 4, half-maximal inhibitory concentration: > 100000 nM
Compound 4: a limit, no number; the forecaster's own chance of this, stated with the estimate: 25%; at least 2.5-fold (0.39 log units) between middle value and limit.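

In this assay, within the data shown here, compound 4 is recorded only as a limit, > 100000 nM, and this is the first exchange of one group for another on this aromatic carbon, para to a large group. The reading against the methyl analogue is an at least 1.9-fold higher number from compound 3 to compound 4 (0.29 log units; that floor lies within the scatter), so chloro is not shown to differ from methyl here, whereas the reading against the other methyl placement is an at least 4.9-fold higher number from compound 2 to compound 4 (0.69 log units; beyond the scatter). The step from compound 1 to compound 4 cannot be read, so chloro and hydrogen remain unordered at this position: the limit of > 100000 nM in this assay, at which 2 of the 4 values shown sit.

The compounds shown leave open whether a methoxy group, a fluorine atom or an amine on this carbon would give a number rather than a limit. They also leave open whether chloro on the ring carbon that carries the methyl group in compound 2 would read closer to compound 2 than to compound 4, so the effect of placement is known for methyl alone.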